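Isobutyl for Cyclopentyl on the Sulfonamide Nitrogen

The source may hold more compounds than are shown below. What is called first, only, known or untested is meant among the compounds shown, and "the series" means these compounds.

The three measured compounds share one core and differ only at the sulfonamide nitrogen. Compound 1 `CCCCNS(=O)(=O)c1ccc(Nc2ncc3c(n2)N(C2CCCC2)[C@H](CC)C(=O)N3C)cc1` carries a butyl there; in an assay for inhibition of serine/threonine-protein kinase PLK2 (Homo sapiens), read by FRET and Z'-LYTE, with a stated time of 1 h (on this read-out higher numbers stand for weaker inhibition and lower numbers for stronger inhibition), compound 1 gives 19.9 nM. Compound 2 `CC[C@@H]1C(=O)N(C)c2cnc(Nc3ccc(S(N)(=O)=O)cc3)nc2N1C1CCCC1` carries hydrogen, and compound 2 gives 10.2 nM. Compound 3 `CC[C@@H]1C(=O)N(C)c2cnc(Nc3ccc(S(=O)(=O)NC4CCCC4)cc3)nc2N1C1CCCC1` carries cyclopentyl, and compound 3 gives 23.9 nM, the highest of the three numbers. The steps into compound 3 were a 1.2-fold higher number from compound 1 to compound 3 (0.08 log units; within the scatter) and a 2.3-fold higher number from compound 2 to compound 3 (0.37 log units; beyond the scatter); the remaining step was a 2.0-fold lower number from compound 1 to compound 2 (0.29 log units; within the scatter).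

Compound 4 `CC[C@@H]1C(=O)N(C)c2cnc(Nc3ccc(S(=O)(=O)NCC(C)C)cc3)nc2N1C1CCCC1` differs from compound 3 by isobutyl in place of cyclopentyl on a sulfonamide nitrogen. Because a 1.2-fold higher number from compound 1 to compound 3 (0.08 log units; within the scatter) exchanged butyl for cyclopentyl, it bears most closely on this change, butyl and isobutyl being close in kind, and that step stayed within the scatter. The step of a 2.3-fold higher number from compound 2 to compound 3 (0.37 log units; beyond the scatter) was only modest. Compound 4 is therefore expected to stay close to the measured values, with an expected step of a 1.2-fold lower number from compound 3 to compound 4 (0.08 log units; within the scatter). The estimate for compound 4 in this assay is 20 nM, with a range from 9 nM to 45 nM.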

Compound 4, half-maximal inhibitory concentration: 21.8 nM
Compound 4: the middle estimate sits 1.1-fold (0.04 log units) below what was measured; the measured number falls inside the stated range.
By their numbers in this assay, from the lowest: compounds 2, 1, 4 and 3 (each within the scatter of the next, the first and the last beyond it).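

Removing the five-membered ring of cyclopentyl in favour of isobutyl leaves the number within the scatter (a 1.1-fold lower number from compound 3 to compound 4 (0.04 log units; within the scatter)), and so does branching the butyl chain of the earlier compound (a 1.1-fold higher number from compound 1 to compound 4 (0.04 log units; within the scatter)). In this assay, butyl, isobutyl and cyclopentyl on the sulfonamide nitrogen therefore cannot be told apart, with or without a ring. Isobutyl also stands modestly beyond the scatter from hydrogen (a 2.1-fold higher number from compound 2 to compound 4 (0.33 log units; beyond the scatter)), as cyclopentyl does (a 2.3-fold higher number from compound 2 to compound 3 (0.37 log units; beyond the scatter)), but butyl goes against this pattern, its step to hydrogen staying within the scatter (a 2.0-fold lower number from compound 1 to compound 2 (0.29 log units; within the scatter)).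

From the compounds shown here alone, whether an amine, a carboxylic acid or a much longer chain on this nitrogen would move the number further stays open. No accompanying measurement explains why these three groups read alike.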